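The source may report more compounds than this note shows. Statements on the series, on what has been measured and on what is new or still open speak of the compounds shown alone.

Measured so far in a functional assay on MC-38 cells (Mus musculus) for antiproliferative activity, read by CCK-8 assay, with a stated time of 48 h; on this read-out higher numbers stand for weaker inhibition and lower numbers for stronger inhibition:
- compound 1 `COc1ccc(/C=C\c2cc(OC)c(OC)c(OC)c2)cc1OCc1ccc(CN2CCCC[C@@H]2C(=O)O)cc1`: > 10000 nM (a limit of the assay, not a number)
- compound 2 `COc1ccc(/C=C\c2cc(OC)c(OC)c(OC)c2)cc1OCc1ccc(CO)cc1`: 5700 nM
- compound 3 `COc1ccc(/C=C\c2cc(OC)c(OC)c(OC)c2)cc1OCc1ccc(CN2CC[C@@H](C(=O)O)C2)cc1`: 6300 nM

Compound 3 cannot be separated from compound 2 on these numbers: a 1.1-fold higher number from compound 2 to compound 3 (0.04 log units; within the scatter). Against compound 1 only floors exist, an at least 1.5-fold lower number from compound 1 to compound 3 (0.20 log units; that floor lies within the scatter) and an at least 1.7-fold lower number from compound 1 to compound 2 (0.24 log units; that floor lies within the scatter), so neither establishes a real gap.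

Next is compound 4 `COc1ccc(/C=C\c2cc(OC)c(OC)c(OC)c2)cc1OCc1ccc(CN2CC[C@@H](O)C2)cc1`, which differs from compound 3 as follows: hydroxy in place of carboxy on a saturated ring carbon. In words, this is hydroxy in place of carboxy on a saturated ring carbon, giving the 3-hydroxypyrrolidin-1-yl group. Among the compounds with values here, no measured pair makes this exchange on the ring. The nearest evidence is a 1.1-fold higher number from compound 2 to compound 3 (0.04 log units; within the scatter), where 3-carboxypyrrolidin-1-yl replaces hydroxy on a saturated chain carbon and the values do not separate. The floors involving compound 1 add little. No step beyond the scatter is therefore expected in this assay, with at most a slight lean toward stronger inhibition. The expected step is a 1.8-fold lower number from compound 3 to compound 4 (0.26 log units; within the scatter). For compound 4 the estimated value is 3500 nM, with an expected range of 1000 nM to 9000 nM.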

Compound 4, half-maximal inhibitory concentration: 6900 nM
Compound 4: middle estimate off by 2.0-fold (0.29 log units), on the low side, and the stated range covers the measured number.
By their numbers in this assay, from the lowest: compounds 2, 3 and 4 (each within the scatter of the next). At a limit, above all of these: compound 1.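

In this assay, hydroxy in place of carboxy on a saturated ring carbon of the five-membered ring, two ring bonds from the ring nitrogen, does not separate the two compounds: a 1.1-fold higher number from compound 3 to compound 4 (0.04 log units; within the scatter). The earlier compounds shown here tested only the carboxy form of this ring against the hydroxy of compound 2, and the 3-hydroxypyrrolidin-1-yl group does not separate from that hydroxy either, with a 1.2-fold higher number from compound 2 to compound 4 (0.08 log units; within the scatter), so compounds 2, 3 and 4 form one group on these numbers, whichever of the three groups is present. Against compound 1 there is only a floor, an at least 1.4-fold lower number from compound 1 to compound 4 (0.16 log units; that floor lies within the scatter), and the entry for compound 1 is a limit of the assay, not a number: the limit of > 10000 nM in this assay, at which 1 of the 4 values shown sits.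

Still open, as far as these compounds go, is whether a primary amine or a methyl ester on the same ring carbon, or the opposite configuration at that carbon, would give a step beyond the scatter. Also open, from the compounds shown here alone, is whether hydroxy in place of carboxy on the six-membered ring of compound 1 would yield a number rather than a limit.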